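The compounds below may be only part of what the source reports. "The series", "measured", "known", "first", "only" and "open" are said of these compounds alone.

In a functional assay on MCF7 cells (Homo sapiens) for antiproliferative activity, read by MTT assay, with stated times of 24 h and 72 h (on this read-out lower numbers stand for stronger inhibition and higher numbers for weaker inhibition), compound 1 (`COc1ccc([C@@H]2[C@H](Oc3ccccc3)C(=O)N2c2cc(OC)c(OC)c(OC)c2)cc1[N+](=O)[O-]`) gives 69000 nM and compound 2 (`COc1ccc([C@@H]2[C@H](Oc3ccccc3)C(=O)N2c2cc(OC)c(OC)c(OC)c2)c([N+](=O)[O-])c1O`) gives 89000 nM. Going by the values given here, only one step has been measured so far: a 1.3-fold higher number from compound 1 to compound 2 (0.11 log units; within the scatter). It lies within the scatter, so compound 2 and compound 1 stand together as a pair, with no separation between them.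

Compound 3 (`COc1cc(N2C(=O)[C@@H](Oc3ccccc3)[C@H]2c2cc(N)c(OC)c(O)c2)cc(OC)c1OC`) keeps the phenoxy and 3,4,5-trimethoxyphenyl groups of compound 2. The change is a group of 10 heavy atoms (7 carbon, 1 nitrogen, 2 oxygen; one six-membered aromatic ring of carbon only) in place of a group of 12 heavy atoms (7 carbon, 1 nitrogen, 4 oxygen; one six-membered aromatic ring of carbon only), on a saturated ring carbon, on a saturated ring carbon of a four-membered non-aromatic ring with 1 nitrogen.

Among the compounds with values here, the single measured step bears on this only loosely. It shows that the group at this place can be changed with no shift beyond the scatter, but both of its compounds retain the nitrogen-containing arrangement that is altered here, so it gives no measure for this change. Any expectation in this assay is therefore uncertain. A shift toward a lower number, beyond the scatter, is expected, and the estimated step is an 11-fold lower number from compound 2 to compound 3 (1.05 log units; beyond the scatter). For compound 3 the estimated value is 8000 nM, with an expected range from 600 nM to 70000 nM.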

Compound 3, half-maximal inhibitory concentration: 8800 nM
Compound 3: middle estimate off by 1.1-fold (0.04 log units), on the low side, within the range that was stated.
By their numbers in this assay, from the lowest: compound 3; then compounds 1 and 2 (each within the scatter of the next).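

In this assay, the saturated ring carbon of the four-membered ring now shows a response to a change of group that compounds 1 and 2 alone could not show. The response is a 10-fold lower number from compound 2 to compound 3 (1.00 log units; beyond the scatter), and a 7.8-fold lower number from compound 1 to compound 3 (0.89 log units; beyond the scatter). Both steps lie beyond the scatter and bring in the same group of 10 heavy atoms, which carries an amine in place of the nitro group of the two groups that leave, so compound 3 stands apart from a pair that remains unseparated. No available evidence accounts for this shift.

Both steps replace the whole aromatic group, and the ring substituents differ in more than the nitrogen-bearing group, so the share of the amine cannot be separated from that of the other differences, including the hydroxyl absent from compound 1. The compounds shown also leave open how the number would respond to a carboxylic acid or an acetamide in place of the amine on the aromatic group, with the phenoxy and 3,4,5-trimethoxyphenyl groups kept as they are.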